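Swapping the heteroaryl amide for a methylcarbamoyl phenyl

The source may report more compounds than this note shows. Statements on the series, on what has been measured and on what is new or still open speak of the compounds shown alone.

Of the compounds shown here, two have been measured in an assay on isolated protein for inhibition of histone acetyltransferase p300 (Homo sapiens), with a stated time of 60 min; a lower number here means a stronger inhibitor, a higher number a weaker inhibitor. Compound 1 `O=C(Nc1ccc2[nH]ccc2n1)[C@H]1CCCN1C(=O)C1(c2cccc(Cl)c2)CCCC1` gives 0.159 nM, while compound 2 `O=C(Nc1cnc2[nH]ncc2c1)[C@H]1CCCN1C(=O)C1(c2cccc(Cl)c2)CCCC1` gives 15.9 nM. Going by the values given here, compound 2 thus stands at the highest of the two numbers, and the only measured step, a 100-fold higher number from compound 1 to compound 2 (2.00 log units; beyond the scatter), shows how strongly the group on the amide-type nitrogen can move the result.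

Compound 3 `CNC(=O)c1ccc(NC(=O)[C@H]2CCCN2C(=O)C2(c3cccc(Cl)c3)CCCC2)cc1` has not yet been measured. It differs from compound 2 by a group of 10 heavy atoms (8 carbon, 1 nitrogen, 1 oxygen; one six-membered aromatic ring of carbon only) in place of a group of 9 heavy atoms (6 carbon, 3 nitrogen; one five-membered aromatic ring with 2 hetero atoms, one six-membered aromatic ring with 1 hetero atom), on an amide-type nitrogen. Among the compounds with values here, no measured step covers this exact change; the step from compound 1 to compound 2 touches the same position and was large, so a large move in either direction cannot be ruled out, but nothing in the data points to one direction over the other. Compound 3 is therefore expected to land near compound 2, with a step of a 1.1-fold lower number from compound 2 to compound 3 (0.03 log units; within the scatter) that is not expected to go beyond the scatter. The estimate for compound 3 in this assay is 15 nM, with a range from 1.5 nM to 150 nM.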

Compound 3, half-maximal inhibitory concentration: 0.794 nM
Compound 3: middle estimate off by 19-fold (1.28 log units), on the high side; the whole stated range lies above it.
By their numbers in this assay, from the lowest: compound 1; then compound 3; then compound 2.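

In this assay, the result shows that this position on the amide-type nitrogen does not need a group with both a five-membered and a six-membered aromatic ring to give a low number: the 4-(methylcarbamoyl)phenyl group, with a single six-membered aromatic ring of carbon only, gives a 20-fold lower number from compound 2 to compound 3 (1.30 log units; beyond the scatter) and so clearly outperforms one of the two-ring groups. The other comparison, a 5.0-fold higher number from compound 1 to compound 3 (0.70 log units; beyond the scatter), shows that the new group still does not match the two-ring group of compound 1, so the three groups fall into a clear order and the two-ring groups do not sit together at one side of it. The compounds carry no further measurement that bears on why the numbers fall in this order.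

What the compounds shown leave open is how much of the gain belongs to the methylcarbamoyl group and how much to the phenyl ring beneath it, a question that an unsubstituted phenyl, a primary carboxamide or a carboxylic acid at the same place on the ring would address. From the compounds shown here alone, it also remains open whether a longer chain on the amide nitrogen of that group, such as ethyl or a dimethylamide, would keep the number this low.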